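Chloro for methoxy: an estimate for compound 4

The compounds below may be only part of what the source reports. "The series", "measured", "known", "first", "only" and "open" are said of these compounds alone.

Measured so far:
compound 1 `Cn1nnnc1SCC(=O)N/N=c1/scc(-c2ccccc2)n1-c1ccccc1` — 56.2%
compound 2 `COc1ccc(-c2cs/c(=N/NC(=O)CSc3ncccn3)n2-c2ccccc2)cc1` — 66.5%
compound 3 `COc1ccc(-c2cs/c(=N/NC(=O)CSc3nnc(C)s3)n2-c2ccccc2)cc1` — 31.5%

In a functional assay on C6 cells (Rattus norvegicus) for cytotoxicity, read by MTT assay, with a stated time of 24 h, tested at 50 ug/mL (a higher number here means a weaker effect of the compound at the concentration tested, a lower number a stronger effect), compound 3 gives 31.5%, the lowest of the three numbers, so its effect on the cells at the tested concentration is the strongest shown. Compound 2 stands furthest from it, and compound 1 lies in between; both gaps lie beyond the scatter.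

Compound 4 `Cc1nnc(SCC(=O)N/N=c2/scc(-c3ccc(Cl)cc3)n2-c2ccccc2)s1` has not yet been measured. It differs from compound 3 in one place:

chloro in place of methoxy on an aromatic carbon

Among the measured compounds shown here, only one measured step is known, and it concerns a different part of the molecule: a number 35 percentage points lower from compound 2 to compound 3 (beyond the scatter), a change of the ring on the sulfur while the 4-methoxyphenyl group stayed in place. For the measured compounds named here, no measured pair shows what replacing methoxy by chloro on the six-membered ring does. Compound 1, which carries an unsubstituted phenyl, also differs in the ring on the sulfur, so its value cannot be set against compound 3 for this change alone. With nothing bearing directly on it, the most reasonable expectation in this assay is a step of no more than the scatter, with a wide range of uncertainty in either direction.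

Compound 4 is therefore estimated at 35%, with a range from 15% to 60%. The expected step is a number 3.5 percentage points higher from compound 3 to compound 4 (within the scatter).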

Compound 4, a percentage reported as activity, at one concentration (the size of the read-out at that concentration, not a potency): 37.9%
Compound 4: the middle estimate sits 2.9 percentage points below what was measured; measured number inside the range.
By their numbers in this assay, from the lowest: compounds 3 and 4 (each within the scatter of the next); then compound 1; then compound 2.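

In this assay, among the compounds shown here, replacing the 4-methoxyphenyl group of compound 3 with the 4-chlorophenyl group of compound 4 gives a number 6.4 percentage points higher from compound 3 to compound 4 (within the scatter), the first measured step at this place on the molecule. With 5-methyl-1,3,4-thiadiazol-2-yl on the sulfur, the strong effect on the cells therefore does not depend on methoxy specifically, and chloro on the same aromatic carbon gives a number that cannot be told apart from it, whereas the change on the sulfur gave a number 35 percentage points lower from compound 2 to compound 3 (beyond the scatter). Nothing available explains why these two groups read alike.

This one pair does not show whether chloro and methoxy would also read alike with pyrimidin-2-yl or another ring on the sulfur, so the result may hold only for this thiadiazole series. Also open, from the compounds shown here alone, is what a different group on that aromatic carbon, such as an amine, a carboxylic acid or a longer alkoxy chain, would do to the number, and whether any such group would move it beyond the usual scatter in either direction.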